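Methyl to trifluoromethyl on the pendant aryl ring

The compounds below may be only part of what the source reports. "The series", "measured", "known", "first", "only" and "open" are said of these compounds alone.

The series keeps one shared core and varies the aryl group on it. Compound 1 `O=C(O)C[C@H](O)C[C@H](O)CCn1c(C(F)(F)F)nc(-c2ccc(F)cc2)c1-c1cccc(Cl)c1` gives 41 nM in an assay on microsomes from liver for inhibition of 3-hydroxy-3-methylglutaryl-coenzyme A reductase (Rattus norvegicus); a lower number here means a stronger inhibitor, a higher number a weaker inhibitor. Compound 2 `COc1cccc(-c2c(-c3ccc(F)cc3)nc(C(F)(F)F)n2CC[C@@H](O)C[C@@H](O)CC(=O)O)c1` gives 135 nM, and compound 3 `Cc1ccc(-c2c(-c3ccc(F)cc3)nc(C(F)(F)F)n2CC[C@@H](O)C[C@@H](O)CC(=O)O)cc1` gives 750 nM. Compound 3 stands highest of the three numbers: the steps leading to it are an 18-fold higher number from compound 1 to compound 3 (1.26 log units; beyond the scatter) and a 5.6-fold higher number from compound 2 to compound 3 (0.74 log units; beyond the scatter), both beyond the scatter, while a 3.3-fold higher number from compound 1 to compound 2 (0.52 log units; beyond the scatter) completes the set.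

Compound 4 `O=C(O)C[C@H](O)C[C@H](O)CCn1c(C(F)(F)F)nc(-c2ccc(F)cc2)c1-c1ccc(C(F)(F)F)cc1` differs from compound 3 by trifluoromethyl in place of methyl on an aromatic carbon: methyl leaves, trifluoromethyl enters, para to a large group. Among the measured compounds shown here, no measured pair exchanges methyl for trifluoromethyl, and no pair keeps 4-methylphenyl's pattern while changing only the group itself, so direct precedent is absent. The measured steps show only that the identity of the group on this ring moves the number by modest to large amounts, with the 4-methylphenyl compound 3 the weakest. The expected step for this change is therefore uncertain in direction and is estimated as a 1.3-fold lower number from compound 3 to compound 4 (0.10 log units; within the scatter), with no firm basis for a large shift either way. Compound 4 is estimated at 600 nM, with a range from 150 nM to 2500 nM.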

Compound 4, half-maximal inhibitory concentration: > 1000 nM
Compound 4 was reported as a limit (the forecaster's own chance of this, stated with the estimate: 5%); middle value at least 1.6-fold (0.22 log units) from the limit.
By their numbers in this assay, from the lowest: compound 1; then compound 2; then compound 3. At a limit, above all of these: compound 4.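

Compound 4 is reported in this assay only as a limit and not as a number: the limit of > 1000 nM in this assay, at which 1 of the 4 values shown sits. Against compound 3 the result gives only a floor, an at least 1.3-fold higher number from compound 3 to compound 4 (0.12 log units; that floor lies within the scatter), so trifluoromethyl in place of methyl, para to a large group, cannot be ordered against methyl, and the true gap could be small or large. The comparisons with the other two compounds are firmer, an at least 7.4-fold higher number from compound 2 to compound 4 (0.86 log units; beyond the scatter) and an at least 24-fold higher number from compound 1 to compound 4 (1.38 log units; beyond the scatter), so among these four compounds the 4-methylphenyl and 4-(trifluoromethyl)phenyl compounds both give higher numbers than the 3-chlorophenyl and 3-methoxyphenyl compounds, with none going against this.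

Chloro and methoxy appear only in the 3-chlorophenyl and 3-methoxyphenyl groups, while methyl and trifluoromethyl appear only para to a large group, so the effect of the group cannot be separated from the effect of its place on the ring. From the compounds shown here alone, whether any group at this place restores a lower number also stays open, for example a nitrile or an amine on the same aromatic carbon.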